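This account rests on a few compounds, and the source may have more. Where it says the series, first, only, none or still open, it means among the compounds named here.

Measured in a functional assay on SGC-7901 cells (Homo sapiens) for antiproliferative activity, read by MTT assay, with a stated time of 72 h; a higher number here means a weaker inhibitor, a lower number a stronger inhibitor:
compound 1 `C#Cc1cccc(Nc2ncnc3c(OC)c(OC)c(OC)cc23)c1` gives 5820 nM
compound 2 `COc1cc2c(Nc3cc(C(F)(F)F)ccc3F)ncnc2c(OC)c1OC` gives 10300 nM
compound 3 `COc1cc2c(Nc3ccc(F)c(Cl)c3F)ncnc2c(OC)c1OC` gives > 30000 nM

Compound 1 stands at the lowest of the two numbers returned in this assay, with compound 2 the nearest and within the usual scatter of it, so no order between the two is claimed. Compound 3 gives only a limit of the assay, with no number attached (the limit of > 30000 nM in this assay, at which 1 of the 3 values shown sits).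

Compound 4 `COc1cc2c(Nc3ccc(Br)c(F)c3)ncnc2c(OC)c1OC` is the next member. It differs from compound 1 by 4-bromo-3-fluorophenyl in place of 3-ethynylphenyl on a nitrogen on an aromatic ring. Within the data shown here, no step between two measured compounds of this kind has been recorded, so the expected size of the change rests on the whole set: the two halogenated anilines of compound 2 and compound 3 sit no lower than compound 1, and the halogenated aniline of compound 4 is expected to behave alike, a step from compound 1 to compound 4 of a 1.5-fold higher number from compound 1 to compound 4 (0.19 log units; within the scatter), upward and close to the scatter. Compound 4 is therefore estimated at 9000 nM in this assay, with a range from 3000 nM to 30000 nM.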

Compound 4, half-maximal inhibitory concentration: > 30000 nM
Compound 4 was reported as a limit (the forecaster's own chance of this, stated with the estimate: 25%); middle value at least 3.3-fold (0.52 log units) from the limit.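

On a nitrogen on an aromatic ring, 4-bromo-3-fluorophenyl in place of 3-ethynylphenyl gives an at least 5.1-fold higher number from compound 1 to compound 4 (0.71 log units; beyond the scatter) in this assay, the only step shown between two compounds that differ in one place. The two groups have the same count of 8 heavy atoms, and neither has a hydrogen-bond donor or acceptor, so these counts do not separate the two results. Compound 4 gives a limit and not a number, and the top of the assay now holds a second compound: the limit of > 30000 nM in this assay, at which 2 of the 4 values shown sit.

On these data alone, the true size of the step stays unknown, as does whether the bromine, the fluorine or the loss of the ethynyl group accounts for it. As far as these compounds go, whether a plain phenyl, or a phenyl carrying a nitrile or an amine, would sit nearer compound 1 or compound 4 also remains open.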